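The source may hold more compounds than are shown below. What is called first, only, known or untested is meant among the compounds shown, and "the series" means these compounds.

Measured so far:
- compound 1 `CC(C)c1cccc(NC(=O)N[C@H](C)c2ccccc2)c1`: 74% in an ADME assay on the whole organism with Oryza sativa as the target, tested at 0.1 uM; on this read-out lower numbers stand for a stronger effect and higher numbers for a weaker effect at the one concentration tested
- compound 2 `CC(C)c1cccc(NC(=O)N[C@@H](C)c2ccccc2)c1`: 95% in this assay

Going by the values given here, compound 1 sits at the lower of the two numbers; the only neighbour is compound 2, and the step of a number 21 percentage points higher from compound 1 to compound 2 (beyond the scatter) rests on the fact that compounds 1 and 2 differ only in the configuration as drawn alone, a change of configuration with no change of substituent.

Compound 3 `C[C@@H](NC(=O)Nc1cccc(F)c1)c1ccccc1` has not been measured. The change from compound 1 is fluoro in place of isopropyl on an aromatic carbon, on an aromatic carbon of a six-membered aromatic ring of carbon only, meta to a large group; the configuration at the saturated chain carbon stays as drawn in compound 1.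

Among the compounds with values here, no measured step bears on this change: the one step in hand concerns configuration only, so it gives no guide to the exchange of a substituent on the aromatic ring. With nothing to go on, no step beyond the scatter is expected in this assay in either direction, and the range is kept wide. For compound 3 the estimate is 78%, between 55% and 100%, which means an expected step of a number 4 percentage points higher from compound 1 to compound 3 (within the scatter).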

Compound 3, a percentage reported as activity, at one concentration (the size of the read-out at that concentration, not a potency): 99%
Estimate against measurement, compound 3: 21 percentage points below; low and high end bracket the measured number.
By their numbers in this assay, from the lowest: compound 1; then compounds 2 and 3 (each within the scatter of the next).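

Fluoro in place of isopropyl on this aromatic carbon, meta to a large group, is not a neutral exchange in this assay: with the configuration at the saturated chain carbon kept as drawn in compound 1, the change gives a number 25 percentage points higher from compound 1 to compound 3 (beyond the scatter). In this single pair, the stronger effect at the one concentration tested goes with isopropyl, so the lower number of compound 1 now depends on the substituent on the aromatic ring as well as on the configuration as drawn. Going by these compounds alone, the only earlier comparison concerns configuration alone and offers no explanation for the exchange of a substituent on the aromatic ring.

One pair cannot show whether the step follows the number of carbons in the substituent or is specific to fluoro, and methyl, ethyl, tert-butyl, chloro or methoxy at the same carbon would separate these readings. Also open, on these data alone, is whether the configuration at the saturated chain carbon still matters once fluoro replaces isopropyl, and how the series responds to the same groups elsewhere on the aromatic ring.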